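The source may hold more compounds than are shown below. What is called first, only, known or untested is meant among the compounds shown, and "the series" means these compounds.

Measured in an ADME assay on Huh-5-2 cells (Homo sapiens) for cytotoxicity, with a stated time of 3 days; a higher number here means that more compound is tolerated, a lower number that less compound is tolerated:
- Compound 1 `CCOC(=O)c1csc([C@H]2[C@@H](COC)C[C@@](CC(C)C)(C(=O)O)N2C(=O)c2ccc(C(C)(C)C)c(OC)c2)n1`: 200000 nM
- Compound 2 `COC[C@H]1C[C@@](CC(C)C)(C(=O)O)N(C(=O)c2ccc(C(C)(C)C)c(OC)c2)[C@H]1COC`: reported only as a limit of the assay, > 120000 nM
- Compound 3 `CC[C@H]1[C@@H](COC)C[C@@](CC(C)C)(C(=O)O)N1C(=O)c1ccc(C(C)(C)C)c(OC)c1`: 200000 nM

Compound 3 stands level with compound 1: the step of no change at the digits printed from compound 1 to compound 3 (within the scatter) shows no movement beyond the scatter. The nearest step to the change at hand is a step that the limit leaves unreadable from compound 2 to compound 3, which also swaps a group on the same saturated chain carbon; its size cannot be read, as it runs into (the limit of > 120000 nM in this assay, at which 1 of the 3 values shown sits). The same is true of a step that the limit leaves unreadable from compound 1 to compound 2. Compound 4 `COC[C@H]1C[C@@](CC(C)C)(C(=O)O)N(C(=O)c2ccc(C(C)(C)C)c(OC)c2)[C@H]1COC(C)=O` has not yet been measured; it differs from compound 3 by acetoxy in place of methyl on a saturated chain carbon bound to a saturated ring carbon. The readable step, from compound 1 to compound 3, changed nothing, and the two steps through compound 2 give no size at all. The step of no change at the digits printed from compound 3 to compound 4 (within the scatter) from compound 3 to compound 4 is therefore expected to stay within the scatter. Compound 4 is estimated at 200000 nM, with a range from 100000 nM to 350000 nM, and a fair chance that this assay again reports only a limit.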

Compound 4, half-maximal cytotoxic concentration: > 120000 nM
Compound 4: no number, only a limit; the forecaster's own chance of this, stated with the estimate: 40%; the middle value does not contradict the limit.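

In this assay compound 4 is reported only as a limit, > 120000 nM, so none of its steps from compound 1, compound 2 or compound 3 can be read: the limit of > 120000 nM in this assay, at which 2 of the 4 values shown sit.

On these data alone, whether acetoxy in place of methyl changes how much compound is tolerated, and where compound 2 and compound 4 truly stand against compound 1 and compound 3, remains open.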